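A Second Group on the Carbonyl Carbon of Compound 2

The source may hold more compounds than are shown below. What is called first, only, known or untested is meant among the compounds shown, and "the series" means these compounds.

Compound 1 `CC1(C)CC(CNC(=O)CCC(=O)O)C(C)(C)N1[O]`: > 300000 nM
Compound 2 `Cc1c(C)c2c(c(C)c1OC(=O)CCC(=O)O)CCC(C)(C(=O)O)O2`: 63000 nM
Compound 3 `Cc1c(C)c2c(c(C)c1OC(=O)CCC(=O)NCC1CC(C)(C)N([O])C1(C)C)CCC(C)(C(=O)NCC1CC(C)(C)N([O])C1(C)C)O2`: 70000 nM

All three compounds were tested in a functional assay on RPMI-8226 cells (Homo sapiens) for cytotoxicity, read by MTT assay, with a stated time of 72 h; a higher number here means a weaker inhibitor, a lower number a stronger inhibitor. Compound 1 gives > 300000 nM, which is a limit of the assay and not a number. That leaves two true numbers in this assay. Compound 2 gives 63000 nM, and its nearest neighbour, compound 3, gives 70000 nM. The two lie within the scatter of each other, so neither can be ranked above the other.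

The next compound to be tested is compound 4 `Cc1c(C)c2c(c(C)c1OC(=O)CCC(=O)O)CCC(C)(C(=O)NC1CC(C)(C)N([O])C1(C)C)O2`, which has not yet been measured. It departs from compound 2 at a single place, on a carbonyl carbon, where the hydroxy group gives way to a larger group: a group of 11 heavy atoms (8 carbon, 2 nitrogen, 1 oxygen; one five-membered non-aromatic ring with 1 hetero atom) in place of one oxygen atom, on a carbonyl carbon. Among the measured compounds shown here, no measured pair differs in one place alone, so no direct step is available as a guide. The expectation leans on compound 3, at 70000 nM, whose number sits within the scatter of compound 2. No change beyond the scatter is expected in this assay, though the uncertainty is wide. The expected change is a 1.1-fold lower number from compound 2 to compound 4 (0.02 log units; within the scatter). For compound 4 the estimated value is 60000 nM, with an expected range from 20000 nM to 180000 nM.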

Compound 4, half-maximal inhibitory concentration: > 300000 nM
Compound 4: only a limit was reported (the forecaster's own chance of this, stated with the estimate: 10%); middle value at least 5.0-fold (0.69 log units) away from the limit.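

Set in place of the hydroxy group on a carbonyl carbon whose other neighbour is a saturated ring carbon, the group of 11 heavy atoms with its five-membered non-aromatic ring gives the first step in this series that can be read at a single place: in this assay there is an at least 4.7-fold higher number from compound 2 to compound 4 (0.67 log units; beyond the scatter). Among the compounds shown here, this shows that the number in this assay responds to a change at this one position, which the earlier compounds could not show, as no two of them differ in one place alone. Compound 4 carries only a limit of the assay, so the step fixes a floor for the size of the change and not the size itself: the limit of > 300000 nM in this assay, at which 2 of the 4 values shown sit.

Going by these compounds, it remains open whether the step follows from removing the hydroxy group or from the particular group that enters, and a simple primary amide or a methyl ester on this carbonyl carbon would help to separate the two. The compounds shown also leave open how a piperidine ring in place of the five-membered ring, or a longer chain leading to that ring, would read in this assay.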